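The source may hold more compounds than are shown below. What is called first, only, known or untested is meant among the compounds shown, and "the series" means these compounds.

Measured compounds:
compound 1, `N#CC1CN1C(=O)Nc1ccc(S(N)(=O)=O)cc1`, gives > 38000 nM
compound 2, `N#CC1CN1C(=O)Nc1cccnc1`, gives 6000 nM
compound 3, `N#CC1CN1C(=O)NC1CCCCC1`, gives 2400 nM

All three values come from a functional assay on WiDr cells (Homo sapiens) for inhibition; a higher number here means a weaker inhibitor, a lower number a stronger inhibitor. For compound 1 the figure is only a limit of the assay, (the limit of > 38000 nM in this assay, at which 1 of the 3 values shown sits), and no number is known for it. Compound 2 and compound 3 do give numbers in this assay, and the value of compound 3 is the lower of the two. Within the data shown here, compound 1 therefore stands apart from both, at the limit, with no measured step linking it to either.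

Compound 4, `N#CC1CN1C(=O)Nc1ccc(C(F)(F)F)cc1`, differs from compound 1 in one place: trifluoromethyl in place of sulfamoyl on an aromatic carbon. The shared core with the nitrile and the urea is unchanged. Because compound 1 sits at the limit of > 38000 nM in this assay, at which 1 of the 3 values shown sits, the size of the step to compound 4 in this assay cannot be anchored in a measured number; what compound 2 and compound 3 show is that this core with another group on the urea nitrogen reaches measurable values. The step from compound 1 to compound 4 is expected to go toward stronger inhibition, by an at least 4.7-fold lower number from compound 1 to compound 4 (0.67 log units; beyond the scatter). Compound 4 is estimated at 8000 nM, with a range from 2000 nM to 40000 nM, and a fair chance that only a limit is reported.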

Compound 4, half-maximal inhibitory concentration: 1300 nM
For compound 4 the middle estimate is 6.2-fold (0.79 log units) above the measured one, outside the stated range (below it).
By their numbers in this assay, from the lowest: compounds 4 and 3 (each within the scatter of the next); then compound 2. At a limit, above all of these: compound 1.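

In this assay, trifluoromethyl in place of sulfamoyl on an aromatic carbon gives an at least 29-fold lower number from compound 1 to compound 4 (1.46 log units; beyond the scatter), a large change that comes from this one position alone. Among these compounds, compounds 2 and 3 showed only that the shared core reaches measurable values with another whole group on the urea nitrogen; this pair shows that, with the rest of the molecule unchanged, the group para to a group of 8 heavy atoms decides whether a number is obtained at all. The two groups have the same count of heavy atoms, 4, yet they differ in their atoms and in their hydrogen-bond donors and acceptors, and compound 1 remains a limit and not a number: the limit of > 38000 nM in this assay, at which 1 of the 4 values shown sits.

A single pair cannot separate which of these differences carries the step, nor give its true size. An amine, a carboxylic acid, a methyl or a chlorine at the same place, or a trifluoromethyl moved to another carbon of the ring, would show whether the step follows the group itself or its position.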